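A few compounds are considered here, and "the series" means these few. Any claim that something is new, unique, unknown or untested is made for them only; others in the source may bear on it.

Compound 1 `C=CS(=O)(=O)N1CCN(c2ncnc3sc(-c4ccc(N5CCN(C)CC5)cc4)cc23)CC1` gives 7550 nM
Compound 2 `C=CS(=O)(=O)N1CCN(c2ncnc3sc(-c4ccc(OC)nc4)cc23)CC1` gives 9270 nM

Both values come from a functional assay on MDA-MB-231 cells (Homo sapiens) for antiproliferative activity, read by MTT assay, with a stated time of 48 h; on this read-out lower numbers stand for stronger inhibition and higher numbers for weaker inhibition. Compound 2, at 9270 nM, sits within the usual scatter of compound 1, at 7550 nM, so the two cannot be ranked. Compound 3 `C=CS(=O)(=O)N1CCN(c2ncnc3sc(C4=CCCCC4)cc23)CC1` has not yet been measured. It carries cyclohex-1-en-1-yl in place of 6-methoxypyridin-3-yl on an aromatic carbon of a five-membered aromatic ring with 1 sulfur, next to the ring sulfur (cyclohex-1-en-1-yl in place of 6-methoxypyridin-3-yl on an aromatic carbon). Among the compounds with values here, no measured step between compounds that differ in one place is available to guide this change. Within the data shown here, the only guide is that the two known values lie close together, so no shift beyond the scatter is expected, in either direction. The estimated change is a 1.2-fold lower number from compound 2 to compound 3 (0.06 log units; within the scatter). The expected value for compound 3 is 8000 nM, with an estimated range from 3000 nM to 20000 nM.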

Compound 3, half-maximal inhibitory concentration: > 50000 nM
Compound 3 gave a limit, no number (the forecaster's own chance of this, stated with the estimate: 10%); at least 6.2-fold (0.79 log units) between middle value and limit.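

In this assay compound 3 gives > 50000 nM, which is a limit and not a number. Placing cyclohex-1-en-1-yl instead of 6-methoxypyridin-3-yl on this aromatic carbon, next to the ring sulfur, gives an at least 5.3-fold higher number from compound 2 to compound 3 (0.73 log units; beyond the scatter), so this position does not accept every ring alike, something the close values of compound 1 and compound 2 could not reveal. The true size of the step stays unknown, as it rests on a limit: the limit of > 50000 nM in this assay, at which 1 of the 3 values shown sits.

The change removes the aromatic ring, the ring nitrogen and the methoxy oxygen all at once, and the compounds shown cannot tell which of these losses matters. A plain phenyl ring or an unsubstituted pyridin-3-yl ring at this position would help to separate them.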